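The compounds below may be only part of what the source reports. "The series", "measured", "known", "first", "only" and "open" are said of these compounds alone.

In a functional assay on HCT-15 cells (Homo sapiens) for antiproliferative activity, read by MTT assay, with a stated time of 72 h (on this read-out higher numbers stand for weaker inhibition and lower numbers for stronger inhibition), compound 1 (`COc1cccc(-n2ccnc2-c2cc(OC)c(OC)c(OC)c2)c1`) gives 17100 nM and compound 2 (`COc1ccc(-n2ccnc2-c2cc(OC)c(OC)c(OC)c2)cc1`) gives 1300 nM as the lower of the two numbers. Going by the values given here, the one measured step, a 13-fold lower number from compound 1 to compound 2 (1.12 log units; beyond the scatter) and large, swaps 3-methoxyphenyl for 4-methoxyphenyl. Compound 3 (`COc1ccc(-n2ccnc2-c2cc(OC)c(OC)c(OC)c2)cc1O`) keeps compound 2 and adds hydroxy in place of hydrogen on an aromatic carbon with hydroxy in place of hydrogen on an aromatic carbon, ortho to a methoxy group and meta to a large group. Among the compounds with values here, no measured step adds a hydroxy, so that step bears only indirectly, as a sign that this ring responds strongly to change. A moderate move to a lower number is expected in this assay, estimated as a 5.2-fold lower number from compound 2 to compound 3 (0.72 log units; beyond the scatter) for this change. Compound 3 is estimated at 250 nM with a range of 30 nM to 1500 nM on present data.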

Compound 3, half-maximal inhibitory concentration: 200 nM
Beside the measured number, compound 3's estimate is 1.3-fold (0.10 log units) above it, and the stated range covers the measured number.
By their numbers in this assay, from the lowest: compound 3; then compound 2; then compound 1.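

In this assay, hydroxy in place of hydrogen on an aromatic carbon, ortho to a methoxy group and meta to a large group, gives a 6.5-fold lower number from compound 2 to compound 3 (0.81 log units; beyond the scatter). The earlier step only moved the methoxy group, whereas this one shows that the 4-methoxyphenyl ring of compound 2 can take an added group with a further drop in the number. Nothing at hand explains this drop. From the compounds shown here alone, whether an amine or a fluorine at this carbon would match hydroxy stays open. So does whether hydroxy would give a similar drop on the 3-methoxyphenyl ring of compound 1.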